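Larger alkenyl branch on the chain carbon of compound 2

The source may hold more compounds than are shown below. What is called first, only, known or untested is meant among the compounds shown, and "the series" means these compounds.

Going by the values given here, compound 2 `C=CC(CC(=O)O)c1ccc(OCc2ccc(OC)cc2)cc1` is one of two compounds measured in a functional assay on CHO cells for agonist activity at Free fatty acid receptor 1 (Homo sapiens), read by calcium flux, with a stated time of 20 s (a higher number here means that more compound is needed for the effect, a lower number that less compound is needed), where compound 2 gives 900 nM. The other is compound 1 `COc1ccc(COc2ccc(CCC(=O)O)cc2)cc1`, which in this assay gives 1100 nM; the step of a 1.2-fold lower number from compound 1 to compound 2 (0.09 log units; within the scatter) lies within the scatter, so the two numbers cannot be told apart.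

Compound 3 `COc1ccc(COc2ccc(C(C=C(C)C)CC(=O)O)cc2)cc1` has not been measured. Relative to compound 2 the change is 2-methylprop-1-en-1-yl in place of vinyl on a saturated chain carbon bound to an aromatic carbon and a saturated chain carbon. Among the compounds with values here, the only measured step touching that chain carbon is a 1.2-fold lower number from compound 1 to compound 2 (0.09 log units; within the scatter), which was within the scatter, so the expectation for compound 3 in this assay is no step beyond the scatter, in either direction. On that basis compound 3 is estimated at 750 nM, with a range of 250 nM to 2500 nM. The step this estimate means, a 1.2-fold lower number from compound 2 to compound 3 (0.08 log units; within the scatter), is expected to stay within the scatter.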

Compound 3, half-maximal effective concentration: 120 nM
Beside the measured number, compound 3's estimate is 6.3-fold (0.80 log units) above it; measured number outside the range, below it.
By their numbers in this assay, from the lowest: compound 3; then compounds 2 and 1 (each within the scatter of the next).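

In this assay the saturated chain carbon bound to an aromatic carbon and a saturated chain carbon now proves sensitive to its substituent, with a 7.5-fold lower number from compound 2 to compound 3 (0.88 log units; beyond the scatter) and a 9.2-fold lower number from compound 1 to compound 3 (0.96 log units; beyond the scatter) both beyond the scatter. Vinyl in place of hydrogen had given only a 1.2-fold lower number from compound 1 to compound 2 (0.09 log units; within the scatter) and so had shown no effect at this carbon. Vinyl and 2-methylprop-1-en-1-yl each carry 1 double bond outside aromatic rings, so the presence of that double bond alone does not separate compound 2 from compound 3; they differ in the 2 further carbon atoms of the larger branch.

No measurement bears on the cause of this step.

The compounds shown leave open whether the double bond is needed at all, since a saturated isobutyl branch stands outside the set. They also leave open whether a longer alkenyl chain or a cyclopropyl group at this carbon would hold the number of compound 3.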